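This account rests on a few compounds, and the source may have more. Where it says the series, first, only, none or still open, it means among the compounds named here.

Measured in a functional assay on HepG2 cells (Homo sapiens) for inhibition, read by MTT assay, with a stated time of 72 h; a higher number here means a weaker inhibitor, a lower number a stronger inhibitor:
compound 1 `Cc1ccc2nc(-c3ccc(NCc4cn(Cc5cc(=O)oc6cc(O)ccc56)nn4)cc3)sc2c1` gives 52800 nM
compound 2 `Cc1ccc2c(Cn3cc(CNc4ccc(-c5nc6ccc(C)cc6s5)cc4)nn3)cc(=O)oc2c1` gives 94700 nM
compound 3 `Cn1c(-c2cn(Cc3cc(=O)oc4cc(O)ccc34)nn2)nc2ccccc21` gives 70700 nM

Compound 2 is obtained from compound 1 by the change (methyl in place of hydroxy on an aromatic carbon), and the step that this change made in this assay is a 1.8-fold higher number from compound 1 to compound 2 (0.25 log units; within the scatter). Compound 4 `Cc1ccc2c(Cn3cc(-c4nc5ccccc5n4C)nn3)cc(=O)oc2c1` has not yet been measured; it arises from compound 3 by methyl in place of hydroxy on an aromatic carbon. The group that leaves, the group that enters and the place of the exchange are described in identical words for both pairs, so the two steps are the same change carried out on two different cores. The difference between the core of compound 1 and the core of compound 3 is not broken down here; in this assay the values of compound 1 and compound 3 lie within the scatter of each other, as do those of compound 3 and compound 2.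

For compound 4 in this assay the expected step is a 1.5-fold higher number from compound 3 to compound 4 (0.17 log units; within the scatter), placed beside the measured step of a 1.8-fold higher number from compound 1 to compound 2 (0.25 log units; within the scatter), because the step of a 1.8-fold higher number from compound 1 to compound 2 (0.25 log units; within the scatter) stayed within the scatter and nothing among these three compounds shows the same change acting differently on the core of compound 3. The estimate for compound 4 is accordingly 105000 nM, with a range from 50000 nM to 250000 nM. All three measured numbers are high, so a limit rather than a number remains possible for compound 4.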

Compound 4, half-maximal inhibitory concentration: 900 nM
For compound 4 the middle estimate is 120-fold (2.07 log units) above the measured one, and the stated range ends above it.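

In this assay compound 4 gives 900 nM and the step for methyl in place of hydroxy on an aromatic carbon is a 79-fold lower number from compound 3 to compound 4 (1.90 log units; beyond the scatter) on the core of compound 3, a large change in this series. The same exchange does not carry from one core to the other as a fixed step: the same change on two cores in this assay, a 1.8-fold higher number (0.25 log units; within the scatter) from compound 1 to compound 2 and a 79-fold lower number (1.90 log units; beyond the scatter) from compound 3 to compound 4, 140-fold (2.15 log units) apart, beyond the scatter of two such steps

Within the data shown here, the result rests on only two matched pairs, and the core of compound 1 and the core of compound 3 differ in more than one place, so it does not show which part of that difference separates the two steps, what lies behind the gap, or how the exchange would behave on any third core.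

Still open, as far as these compounds go, is whether the large step on the core of compound 3 follows from the entering methyl or from the leaving hydroxy, a question that a methoxy group, a chlorine or plain hydrogen on the same aromatic carbon could help to settle. Also open, from the compounds shown here alone, is whether an amine or a longer chain in that place would keep the value of compound 4 in this assay.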